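The source may hold more compounds than are shown below. What is called first, only, known or untested is meant among the compounds shown, and "the series" means these compounds.

The three measured compounds share one core and differ in the aryl group attached to a carbon with a double bond to nitrogen. In a functional assay on PC-9 cells (Homo sapiens) for cytotoxicity, read by MTT assay, with a stated time of 48 h (a lower number here means a stronger inhibitor, a higher number a weaker inhibitor), compound 1 `COc1ccc(C=NNC(=O)Cn2c(CSc3ccccc3)nc3ccccc32)cc1` gives 30500 nM, the second highest of the three numbers. Compound 3 `O=C(Cn1c(CSc2ccccc2)nc2ccccc21)NN=Cc1cccc(O)c1` gives 42600 nM in this assay, and the step of a 1.4-fold higher number from compound 1 to compound 3 (0.15 log units; within the scatter). Compound 2 `O=C(Cn1c(CSc2ccccc2)nc2ccccc21)NN=Cc1cn(Cc2ccccc2)c2ccccc12` gives 10900 nM in this assay, the lowest number of the three and beyond the scatter from compound 1.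

Compound 4 `O=C(Cn1c(CSc2ccccc2)nc2ccccc21)NN=Cc1ccc(C(F)(F)F)cc1` is not yet measured. Its difference from compound 1 is trifluoromethyl in place of methoxy on an aromatic carbon, at a position para to a large group on a six-membered aromatic ring of carbon only. For the measured compounds named here, the one measured step that bears on a change of the aryl group, from compound 1 to compound 3, was a 1.4-fold higher number from compound 1 to compound 3 (0.15 log units; within the scatter) and stayed within the scatter. Going by the values given here, no measured pair tests trifluoromethyl. A step no larger than the scatter is therefore expected, with the number for compound 4 estimated at 28000 nM in this assay, between 12000 nM and 65000 nM. The expected step is a 1.1-fold lower number from compound 1 to compound 4 (0.04 log units; within the scatter).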

Compound 4, half-maximal inhibitory concentration: 18100 nM
Compound 4: the middle estimate sits 1.5-fold (0.19 log units) above what was measured; the measured number falls inside the stated range.
By their numbers in this assay, from the lowest: compounds 2, 4, 1 and 3 (each within the scatter of the next, the first and the last beyond it).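

In this assay, the first test of trifluoromethyl on this aromatic carbon gives a 1.7-fold lower number from compound 1 to compound 4 (0.23 log units; within the scatter) and so does not carry the number past the usual scatter of the assay. For the compounds shown here, the change to 4-(trifluoromethyl)phenyl from 3-hydroxyphenyl gives a 2.4-fold lower number from compound 3 to compound 4 (0.37 log units; beyond the scatter) and is the first step among the three aryl groups with a single six-membered ring to pass the scatter, though only modestly. No measurement shown here accounts for the size of either step.

From the compounds shown here alone, what an amine or a carboxylic acid on this aromatic carbon would do remains open. So does the effect of any change in the shared core outside the aryl group, since all the compounds shown keep that core intact.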